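This account rests on a few compounds, and the source may have more. Where it says the series, first, only, none or still open, it means among the compounds named here.

Measured compounds:
- compound 1 `Cc1nc(NC(=O)Cn2nnc(-c3ccccc3)n2)n(-c2ccccc2)n1`: "not active" (no number reported)
- compound 2 `Cc1cc(NC(=O)Cn2nnc(-c3ccc(Cl)c(Cl)c3)n2)n(C2CCCCC2)n1`: 84%

In an assay on HEK293 cells for activation of Kir3.1/Kir3.2 (Homo sapiens), read by thallium flux (on this read-out lower numbers stand for smaller maximal responses and higher numbers for larger maximal responses), compound 1 gives "not active" (no number reported), which is an entry without a number. In this assay compound 2 gives 84%; it is the only number shown in this assay, with one further entry recorded without a number, so compound 2 cannot be ranked against anything measured. Going by the values given here, no step between two measured compounds that differ in one place is available, so the effect of a change on the aryl group attached to the core is not documented by the series itself.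

Compound 3 `Cc1cc(NC(=O)Cn2nnc(-c3ccc(C(F)(F)F)cc3)n2)n(C2CCCCC2)n1` differs from compound 2 by 4-(trifluoromethyl)phenyl in place of 3,4-dichlorophenyl on an aromatic carbon. Among the compounds with values here, with no measured step to lean on, the expectation for the step of a number 12 percentage points lower from compound 2 to compound 3 (beyond the scatter) is a small change, somewhat downward but possibly within the usual scatter, since compound 2 keeps the same core and the same cyclohexyl group and its value 84% gives the only anchor. Compound 3 is therefore estimated at 72% in this assay, with a range from 45% to 95%.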

Compound 3, largest response reached (Emax), in percent of the reference or control that the assay uses: 94%
Estimate against measurement, compound 3: 22 percentage points below, and the stated range covers the measured number.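

In this assay the aromatic carbon of the five-membered aromatic ring with 4 nitrogen now has its first measured step: a number 10 percentage points higher from compound 2 to compound 3 (within the scatter) with 4-(trifluoromethyl)phenyl in place of 3,4-dichlorophenyl. Before this step, the series held a single number for this cyclohexyl-bearing scaffold and nothing on how the aryl group at this position could be exchanged. The step shows that these two substituted phenyl groups are interchangeable here within the scatter, so this read-out does not separate the two chlorine atoms from the trifluoromethyl group, and no measurement shown offers a reason for this outcome.

Compound 1 with its entry "not active" (no number reported) differs from compound 2 in more than one place, so the absence of a number cannot be assigned to the unsubstituted phenyl on the five-membered ring, the phenyl in place of cyclohexyl or the change in the core. The compounds shown also leave open how this position would respond to a phenyl carrying a carboxylic acid or a dimethylamino group, or to a piperidine in place of the aryl ring.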